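A few compounds are considered here, and "the series" means these few. Any claim that something is new, unique, unknown or untested is made for them only; others in the source may bear on it.

Measured compounds in a functional assay on MDA-MB-435 cells (Homo sapiens) for inhibition, read by sulforhodamine B assay, with a stated time of 48 h; on this read-out lower numbers stand for stronger inhibition and higher numbers for weaker inhibition:
- compound 1 `COc1ccc(N(C)c2nc(C)nc3c2CCC3)cc1` gives 7 nM
- compound 2 `COc1ccc(N(C)c2ncnc3c2CCC3)cc1` gives 43 nM
- compound 3 `COc1ccc(N(C)c2nc(C)nc3c2C(C)CC3)cc1` gives 18.8 nM

Compound 1 stands lowest of the three numbers, which on this read-out means the strongest inhibition. The nearest measured neighbour is compound 3, reached by the step of a 2.7-fold higher number from compound 1 to compound 3 (0.43 log units; beyond the scatter), and the furthest is compound 2, reached by the step of a 6.1-fold higher number from compound 1 to compound 2 (0.79 log units; beyond the scatter). Both steps lie beyond the scatter, so every change made so far at the shared core of compound 1 has weakened inhibition.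

Compound 4 `CCOc1ccc(N(C)c2nc(C)nc3c2CCC3)cc1` is not yet measured. It differs from compound 1 by methyl in place of hydrogen on a saturated chain carbon bound to an oxygen on an aromatic ring. Neither measured step bears directly on this place: the step from compound 1 to compound 2 alters an aromatic carbon, and the step from compound 1 to compound 3 alters a saturated ring carbon, while the change in compound 4 sits on the chain beside the aromatic oxygen. For the measured compounds named here, the two measured steps show only that the core is sensitive to small changes. For compound 4 a small step in this assay, possibly toward a higher number but likely within the scatter, is expected. Compound 4 is estimated at 12 nM, with a range from 4 nM to 40 nM. The expected step is a 1.7-fold higher number from compound 1 to compound 4 (0.23 log units; within the scatter).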

Compound 4, half-maximal inhibitory concentration: 15.1 nM
For compound 4 the middle estimate is 1.3-fold (0.10 log units) below the measured one; the measured number falls inside the stated range.
By their numbers in this assay, from the lowest: compound 1; then compounds 4 and 3 (each within the scatter of the next); then compound 2.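

The earlier steps shown here altered an aromatic carbon and a saturated ring carbon, whereas this one alters a saturated chain carbon bound to an oxygen on an aromatic ring. In this assay going from methoxy to ethoxy gives a 2.2-fold higher number from compound 1 to compound 4 (0.33 log units; beyond the scatter) and so shows that this place also responds to a single added methyl, with inhibition modestly weaker but not lost. No measurement shown here explains why the number moves in this direction.

A single pair cannot show whether a longer chain such as propoxy would move the number further. On these data alone, how a hydroxyl, an amine or a halogen such as fluorine would behave in place of the methoxy group also remains open.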